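Replacing phenylsulfonyl on an amine nitrogen

The source may hold more compounds than are shown below. What is called first, only, known or untested is meant among the compounds shown, and "the series" means these compounds.

Measured in an ADME assay on Karpas-1106P cells (Homo sapiens) for cytotoxicity; on this read-out lower numbers stand for an effect already at smaller amounts and higher numbers for an effect only at larger amounts of compound:
- Compound 1 `Cc1ccc(S(=O)(=O)N[C@@H](CC(=O)NC(C)(C)C)C(=O)NCCNC(=O)NCc2ccccc2)cc1`: > 11100 nM, a limit
- Compound 2 `Cc1ccc(S(=O)(=O)N[C@@H](CC(=O)NC(C)(C)C)C(=O)NCCNS(=O)(=O)c2ccccc2)cc1`: > 11100 nM, a limit

Compound 2 has no exact number, only the limit > 11100 nM. Compound 3 `Cc1ccc(S(=O)(=O)N[C@@H](CC(=O)NC(C)(C)C)C(=O)NCCNC(=O)c2cccc(C(F)(F)F)c2)cc1` carries (3-(trifluoromethyl)phenyl)carbonyl in place of phenylsulfonyl on an amine nitrogen. Among the compounds with values here, the one measured change at this place, a step that the two limits leave unreadable from compound 1 to compound 2, has no readable size, and both compounds sit at the same limit: the limit of > 11100 nM in this assay, at which 2 of the 2 values shown sit. It offers no size to carry over, so no step beyond the scatter is expected in this assay. The expected step is a step that the limit leaves unreadable from compound 2 to compound 3. Compound 3 is expected at 12000 nM, with an estimated range of 4000 nM to 30000 nM.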

Compound 3, half-maximal effective concentration: > 11100 nM
Compound 3 ended at the assay's limit; the forecaster's own chance of this, stated with the estimate: 75%; the middle value does not contradict the limit.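

Compound 1, compound 2 and compound 3 all end at the same limit, so no step between them can be read: the limit of > 11100 nM in this assay, at which 3 of the 3 values shown sit.

On these data alone, how benzylcarbamoyl, phenylsulfonyl and (3-(trifluoromethyl)phenyl)carbonyl on the amine nitrogen compare in this assay stays open.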